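Opening the amine ring of compound 1

The source may report more compounds than this note shows. Statements on the series, on what has been measured and on what is new or still open speak of the compounds shown alone.

Compound 1 `CC(C)=CCc1cc(C(=O)Nc2cc3ccc(OCC4CCCNC4)c(C)c3oc2=O)ccc1O` is the reference point. In a functional assay on MCF7 cells (Homo sapiens) for antiproliferative activity (a higher number here means a weaker inhibitor, a lower number a stronger inhibitor), compound 1 gives 790 nM, the smallest of the three numbers measured, though both neighbours sit within the scatter of it. Compound 2 `CCNCCCOc1ccc2cc(NC(=O)c3ccc(O)c(CC=C(C)C)c3)c(=O)oc2c1C` gives 980 nM, and compound 3 `CC(C)=CCc1cc(C(=O)Nc2cc3ccc(OCCCNCC(C)C)c(C)c3oc2=O)ccc1O` gives 1320 nM. The steps of a 1.2-fold higher number from compound 1 to compound 2 (0.09 log units; within the scatter) and a 1.7-fold higher number from compound 1 to compound 3 (0.22 log units; within the scatter) each replace the piperidin-3-yl with an open-chain amine and change little; the step of a 1.3-fold higher number from compound 2 to compound 3 (0.13 log units; within the scatter) between the two open chains is also small.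

Compound 4 `CC(C)=CCc1cc(C(=O)Nc2cc3ccc(OCCCN(C)C(C)(C)C)c(C)c3oc2=O)ccc1O` differs from compound 1 by 2-(methyl(tert-butyl)amino)ethyl in place of piperidin-3-yl on a saturated chain carbon bound to an oxygen on an aromatic ring. As in the two earlier steps, the ring gives way to an open chain carrying an amine, but here the chain holds no hydrogen-bond donor. Because the earlier ring-opening steps a 1.2-fold higher number from compound 1 to compound 2 (0.09 log units; within the scatter) and a 1.7-fold higher number from compound 1 to compound 3 (0.22 log units; within the scatter) stayed within the scatter, a comparably small step, if anything towards a higher number, is expected. Compound 4 is therefore estimated at 1500 nM, with a range from 600 nM to 4000 nM, a step of a 1.9-fold higher number from compound 1 to compound 4 (0.28 log units; within the scatter).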

Compound 4, half-maximal inhibitory concentration: 1140 nM
Estimate against measurement, compound 4: 1.3-fold (0.12 log units) above, within the range that was stated.
By their numbers in this assay, from the lowest: compounds 1, 2, 4 and 3 (each within the scatter of the next).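

Replacing piperidin-3-yl with 2-(methyl(tert-butyl)amino)ethyl gives a step that stays within the scatter in this assay (a 1.4-fold higher number from compound 1 to compound 4 (0.16 log units; within the scatter)), so at this position the chain can hold an amine with 0 hydrogen-bond donors and no ring without a measurable shift. The comparisons among the open chains agree: methyl(tert-butyl)amino in place of isobutylamino gives a small step (a 1.2-fold lower number from compound 3 to compound 4 (0.06 log units; within the scatter)), and methyl(tert-butyl)amino in place of ethylamino gives another (a 1.2-fold higher number from compound 2 to compound 4 (0.07 log units; within the scatter)). No measurement shown here accounts for how close these numbers lie.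

From the compounds shown here alone, all four compounds carry an amine on this chain, so it remains open whether the nitrogen matters at all. A chain ending in a hydroxyl group or a carboxylic acid, or a longer chain, would test how much this position tolerates.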